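A few compounds are considered here, and "the series" means these few. Any claim that something is new, unique, unknown or untested is made for them only; others in the source may bear on it.

Values in a functional assay on MCF7 cells (Homo sapiens) for cytotoxicity, read by WST assay, with a stated time of 72 h (on this read-out higher numbers stand for weaker inhibition and lower numbers for stronger inhibition), so far:
- compound 1 `O=C1Nc2c(ccc(F)c2F)C1(c1ccncc1)c1ccc(O)cc1` gives 37 nM
- compound 2 `O=C1Nc2c(ccc(F)c2F)C1(c1ccc(O)cc1)c1cccnc1` gives 63 nM
- compound 3 `CCCCCC1(c2ccc(O)cc2)C(=O)Nc2c1ccc(F)c2F` gives 96 nM

Compound 3 sits within the scatter of compound 2 and gives a higher number than compound 1. Compound 4 `O=C1Nc2c(ccc(F)c2F)C1(c1ccc(O)cc1)C1CCCCCC1` differs from compound 3 by cycloheptyl in place of pentyl on a saturated ring carbon. Among the compounds with values here, two measured steps bear on that carbon, one of a 2.6-fold higher number from compound 1 to compound 3 (0.41 log units; beyond the scatter) and one of a 1.5-fold higher number from compound 2 to compound 3 (0.18 log units; within the scatter) and neither involves a saturated ring, so the evidence is indirect. Both steps are small, so no step beyond the scatter is expected in this assay and the lean towards a lower number is slight. The expected change is a 1.6-fold lower number from compound 3 to compound 4 (0.20 log units; within the scatter) in size. Compound 4 is estimated at 60 nM (expected range 20 nM to 200 nM) in this read-out.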

Compound 4, half-maximal inhibitory concentration: 1.2 nM
Compound 4: the middle estimate sits 50-fold (1.70 log units) above what was measured, and the stated range ends above it.
By their numbers in this assay, from the lowest: compound 4; then compounds 1, 2 and 3 (each within the scatter of the next, the first and the last beyond it).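

On the saturated ring carbon, cycloheptyl brings an 80-fold lower number from compound 3 to compound 4 (1.90 log units; beyond the scatter) and a 53-fold lower number from compound 2 to compound 4 (1.72 log units; beyond the scatter) and a 31-fold lower number from compound 1 to compound 4 (1.49 log units; beyond the scatter) in this assay. Each of these steps is larger than any seen among pentyl, pyridin-3-yl and pyridin-4-yl, so this position tolerates these groups and also responds strongly to the choice of group. No measurement on hand accounts for the gain. As far as these compounds go, whether it depends on the seven-membered ring remains open. Cyclopentyl, cyclohexyl or a heptyl chain on this carbon would separate the effect of the ring from that of carbon count.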